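Methoxy for Hydroxy on a Chlorophenyl Ring in Glioblastoma Cells

The source may hold more compounds than are shown below. What is called first, only, known or untested is meant among the compounds shown, and "the series" means these compounds.

Three compounds have been measured in a functional assay on SNB-19 cells (Homo sapiens) for inhibition, read by sulforhodamine B assay, with a stated time of 48 h, tested at 10 uM; on this read-out lower numbers stand for a stronger effect and higher numbers for a weaker effect at the one concentration tested:

compound 1 `O=C(Nc1cccc(-n2cc(-c3ccncc3)c(-c3cc(O)cc(Cl)c3)n2)c1)Nc1ccc(Cl)c(Cl)c1`: 30.8%
compound 2 `COc1cc(Cl)cc(-c2nn(-c3cccc(NC(=O)Nc4ccc(Cl)c(Cl)c4)c3)cc2-c2ccncc2)c1`: 17.8%
compound 3 `O=C(Nc1cccc(-n2cc(-c3ccncc3)c(-c3cc(O)cc(Cl)c3)n2)c1)c1cc(C(F)(F)F)cc(C(F)(F)F)c1`: 63.1%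

Compound 1 and compound 2 differ by one change, (methyl in place of hydrogen on an oxygen on an aromatic ring), and that change produced the step of a number 13 percentage points lower from compound 1 to compound 2 (beyond the scatter). Compound 3 carries a different core from compound 1; how the two cores differ is not broken down here, and compound 3 stands highest of the three numbers in this assay.

Compound 4 `COc1cc(Cl)cc(-c2nn(-c3cccc(NC(=O)c4cc(C(F)(F)F)cc(C(F)(F)F)c4)c3)cc2-c2ccncc2)c1` is not yet measured. For the measured compounds named here, it arises from compound 3 by methyl in place of hydrogen on an oxygen on an aromatic ring, the same change at the same place as the one from compound 1 to compound 2. Going by the values given here, because that earlier change gave a number 13 percentage points lower from compound 1 to compound 2 (beyond the scatter), a step of similar direction and size, a number 13.1 percentage points lower from compound 3 to compound 4 (beyond the scatter), is expected here, though only one prior example supports it. Compound 4 is therefore estimated to give about 50%, most likely between 35% and 68%.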

Compound 4, a percentage reported as activity, at one concentration (the size of the read-out at that concentration, not a potency): 86.4%
Compound 4: the middle estimate sits 36.4 percentage points below what was measured; measured number above the stated range.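

Methoxy in place of hydroxy on the chlorophenyl ring gave a number 23.3 percentage points higher from compound 3 to compound 4 (beyond the scatter) in this assay, so the weaker effect at this one concentration runs against the stronger effect seen on the other core. Set beside the earlier step, the same change moved the read-out in opposite directions on the two cores: the same change on two cores in this assay, a number 13 percentage points lower (beyond the scatter) from compound 1 to compound 2 and a number 23.3 percentage points higher (beyond the scatter) from compound 3 to compound 4, 36.3 percentage points apart, beyond the scatter of two such steps

This shows that, in this series, the step from one core does not carry to the other, but with one pair per core it does not show why the two differ. The compounds shown leave open which part of the two cores decides the direction of the step. They also leave open how an ethoxy group or an amine at the same place would read in this assay.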